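From methoxy to tert-butyl on an aromatic ring

This account rests on a few compounds, and the source may have more. Where it says the series, first, only, none or still open, it means among the compounds named here.

- Compound 1 `COc1ccc(/C=C2\CN(C)C/C(=C\c3ccccc3F)C2=O)cc1`: 12300 nM
- Compound 2 `COc1ccc(/C=C2\CN(C)C/C(=C\c3ccccc3F)C2=O)cc1OC`: 8760 nM
- Compound 3 `COc1cc(/C=C2\CN(C)C/C(=C\c3ccccc3F)C2=O)cc(OC)c1`: 1240 nM

In a functional assay on HepG2 cells (Homo sapiens) for cytotoxicity, read by MTT assay, with a stated time of 24 h (a lower number here means a stronger inhibitor, a higher number a weaker inhibitor), compound 1 has the highest number of the three. Compound 2 lies within the scatter of it, while compound 3 sits clearly lower but differs from compound 1 in more than one place. The unmeasured compound 4 `CN1C/C(=C\c2ccc(C(C)(C)C)cc2)C(=O)/C(=C/c2ccccc2F)C1` puts tert-butyl in place of methoxy on an aromatic carbon. Among the compounds with values here, only one measured step bears on this, a 1.4-fold lower number from compound 1 to compound 2 (0.15 log units; within the scatter), and it is a different change on the same ring. It stays within the scatter, so no step beyond the scatter is expected, though this guide is weak. The estimated step is a 1.2-fold lower number from compound 1 to compound 4 (0.09 log units; within the scatter). Compound 4 is expected at 10000 nM, with an estimated range of 3500 nM to 25000 nM.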

Compound 4, half-maximal inhibitory concentration: 9120 nM
The estimate for compound 4 lay 1.1-fold (0.04 log units) above the measured number; measured number inside the range.
By their numbers in this assay, from the lowest: compound 3; then compounds 2, 4 and 1 (each within the scatter of the next).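

In this assay, tert-butyl in place of methoxy on this aromatic carbon gives a 1.3-fold lower number from compound 1 to compound 4 (0.13 log units; within the scatter), so the number stays within the scatter. Here, a swap from two heavy atoms to four, with the one hydrogen-bond acceptor of methoxy gone, leaves the reading in the range of compound 1, which the earlier step, an added methoxy, could not show. No evidence on hand accounts for this result. From the compounds shown here alone, whether an amine or a carboxylic acid on the same carbon would also stay within the scatter remains open.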